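A Benzyl Swap in an Imidazole Series Awaits Cytotoxicity

A few compounds are considered here, and "the series" means these few. Any claim that something is new, unique, unknown or untested is made for them only; others in the source may bear on it.

Compound 2 `COC(=O)c1ccc(NCc2cncn2Cc2ccc(OC)cc2)cc1-c1ccccc1` carries a 4-methoxybenzyl group on its shared core, and in a toxicity assay on NIH3T3 cells (Mus musculus) for cytotoxicity, read by resazurin assay (a higher number here means that more compound is needed for the effect, a lower number that less compound is needed), compound 2 has "not determined" (no result reported), so no number fixes where it stands. The two related compounds that were measured both sit at a limit of the assay. Compound 1 `Nc1cc(-c2ccccc2)ccc1Cn1cncc1CNc1ccc(-c2cncs2)c(-c2ccccc2)c1` gives > 1000 nM in this assay, a limit rather than a number. Compound 3 `c1ccc(Cn2cncc2CNc2cccc(-c3cccnc3)c2)cc1` likewise gives > 1000 nM in this assay, again a limit. For the measured compounds named here, this is the limit of > 1000 nM in this assay, at which 2 of the 3 values shown sit, and it is the only evidence available for the series. Compound 4 `COC(=O)c1ccc(NCc2cncn2Cc2cccc(N)c2)cc1-c1ccccc1` differs from compound 2 by 3-aminophenyl in place of 4-methoxyphenyl on a saturated chain carbon bound to an aromatic nitrogen. Going by the values given here, no measured step in this assay connects compound 2 to any other compound, so no size of change can be read from the data; the expectation for this step is none beyond the scatter, and the more likely outcome is that compound 4 also reaches only the limit. Compound 4 is therefore expected to give about 1500 nM in this assay, within a range from 600 nM to 5000 nM.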

Compound 4, half-maximal effective concentration: > 10000 nM
Compound 4: no number, only a limit (the forecaster's own chance of this, stated with the estimate: 70%); middle value at least 6.6-fold (0.82 log units) away from the limit.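

In this assay compound 4 gives > 10000 nM, which is a limit and not a number. For the compounds shown here, compound 2 reads "not determined" (no result reported), so no step between compound 2 and compound 4 can be read. The compounds shown leave open whether the change from 4-methoxybenzyl to 3-aminobenzyl alters cytotoxicity at all.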